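Compound 2 loses its 1-methyl-1H-pyrazol-4-yl group

A few compounds are considered here, and "the series" means these few. Any claim that something is new, unique, unknown or untested is made for them only; others in the source may bear on it.

In a physicochemical assay for solubility, read by spectrophotometry, at pH 6.8 (a higher number here means a more soluble compound, a lower number a less soluble compound), compound 1 `Cn1cc(-c2ccc(N(C(=O)NCc3ccccc3)[C@H]3CC[C@H](Nc4ccc(C#N)cn4)CC3)cc2)ccc1=O` gives 7.7 ug/mL, while compound 2 `Cn1cc(-c2ccc(N(C(=O)NCc3ccccc3)[C@H]3CC[C@H](Nc4ccc(C#N)cn4)CC3)cc2)cn1` gives 0.33 ug/mL, the lower of the two numbers. Compound 3 `N#Cc1ccc(N[C@H]2CC[C@H](N(C(=O)NCc3ccccc3)c3ccccc3)CC2)nc1` carries hydrogen in place of 1-methyl-1H-pyrazol-4-yl on an aromatic carbon. For the measured compounds named here, the one measured step at that carbon, a 23-fold lower number from compound 1 to compound 2 (1.37 log units; beyond the scatter), was large. It swapped one group for another and removed none, so it suggests that this carbon matters but fixes no direction. A moderate rise is tentatively expected, namely a 4.5-fold higher number from compound 2 to compound 3 (0.66 log units; beyond the scatter). Compound 3 is estimated at 1.5 ug/mL, with an expected range of 0.3 ug/mL to 10 ug/mL.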

Compound 3, solubility: 4 ug/mL
For compound 3 the middle estimate is 2.7-fold (0.43 log units) below the measured one, and the stated range covers the measured number.
By their numbers in this assay, from the lowest: compound 2; then compounds 3 and 1 (each within the scatter of the next).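

In this assay, for the compounds shown here, the bare carbon gives the first direct reading of the 1-methyl-1H-pyrazol-4-yl group, with a 12-fold higher number from compound 2 to compound 3 (1.08 log units; beyond the scatter) on its removal, so the low number goes with that group rather than with the shared core. The other group at this carbon does not separate from hydrogen, with a 1.9-fold lower number from compound 1 to compound 3 (0.28 log units; within the scatter) across that change. Nothing given here accounts for this difference between the two groups. Going by these compounds, whether an amine or a carboxylic acid on this carbon would stay level with hydrogen or drop toward compound 2 remains open.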